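A few compounds are considered here, and "the series" means these few. Any claim that something is new, unique, unknown or untested is made for them only; others in the source may bear on it.

In a functional assay on FM3A cells (Mus musculus) for inhibition, read by cell counting, with a stated time of 2 days (a higher number here means a weaker inhibitor, a lower number a stronger inhibitor), compound 1 `C=C(Br)C(=O)Nc1cccc(-c2cn3nc(-c4ccccc4)sc3n2)c1` gives 900 nM. Compound 2 `C=C(Br)C(=O)Nc1cccc(-c2cn3nc(-c4ccc(C)cc4)sc3n2)c1` gives 1200 nM, and compound 3 `COc1cccc(-c2nn3cc(-c4cccc(N)c4)nc3s2)c1` gives 29000 nM. Compound 2 thus stands second highest of the three numbers: the step of a 1.3-fold higher number from compound 1 to compound 2 (0.12 log units; within the scatter) is within the scatter, whereas compound 3 sits well higher, beyond the scatter. Compound 3 differs from compound 2 in more than one place, so its number says nothing on its own about a single substituent.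

Compound 4 `C=C(Br)C(=O)Nc1cccc(-c2cn3nc(-c4ccc(OC)cc4)sc3n2)c1` differs from compound 2 by methoxy in place of methyl on an aromatic carbon. Among the measured compounds shown here, the only measured step at this place, a 1.3-fold higher number from compound 1 to compound 2 (0.12 log units; within the scatter), is within the scatter, and no step exchanging methyl for methoxy has been measured anywhere in the set. The change is small in what it counts, so no step beyond the scatter is expected in this assay in either direction. Compound 4 is therefore expected at 1200 nM, with a range from 500 nM to 3000 nM. The step this estimate means, no change at the digits printed from compound 2 to compound 4 (within the scatter), is expected to stay within the scatter.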

Compound 4, half-maximal inhibitory concentration: 890 nM
The estimate for compound 4 lay 1.3-fold (0.13 log units) above the measured number; the measured number falls inside the stated range.
By their numbers in this assay, from the lowest: compounds 4, 1 and 2 (each within the scatter of the next); then compound 3.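

The step of a 1.3-fold lower number from compound 2 to compound 4 (0.13 log units; within the scatter) and the step of a 1.0-fold lower number from compound 1 to compound 4 (0.00 log units; within the scatter) show that in this assay 4-methylphenyl can give way to 4-methoxyphenyl without a change that can be read. This place on the six-membered aromatic ring, para to a large group, now carries hydrogen, methyl and methoxy across compounds 1, 2 and 4, and the one hydrogen-bond acceptor that enters with methoxy comes with no step beyond the scatter. Nothing available bears on the reason for this flat result.

Still open, on these data alone, is whether an amine, a carboxylic acid or a longer chain such as butoxy at this place would give a step beyond the scatter in this assay at all. Compound 3 differs from these compounds in more than one place, so no single change can be held to account for its number.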